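Metabolic stability across replacements of the oxazole substituent

The source may hold more compounds than are shown below. What is called first, only, known or untested is meant among the compounds shown, and "the series" means these compounds.

Measured so far:
compound 1 `COc1cc(-c2cnn3cc(OC)c(-c4cc(C)no4)nc23)ccn1` — 62%
compound 2 `COc1cc(-c2cnn3cc(OC)c(C4CCCC4)nc23)ccn1` — 7%
compound 3 `COc1cc(-c2cnn3cc(OC)c(C4CCOC4)nc23)ccn1` — 34%

In an ADME assay on microsomes from liver (Rattus norvegicus) for metabolic stability, with a stated time of 60 min, tested at 1 uM (a higher number here means that more of the compound is left, a lower number that less of the compound is left), compound 1 stands highest of the three numbers. The nearest is compound 3, reached by the step of a number 28 percentage points lower from compound 1 to compound 3 (beyond the scatter); the furthest is compound 2, reached by the step of a number 55 percentage points lower from compound 1 to compound 2 (beyond the scatter). Between the two ring replacements themselves the step of a number 27 percentage points higher from compound 2 to compound 3 (beyond the scatter) runs in favour of compound 3.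

The next compound, compound 4 `COc1cc(-c2cnn3cc(OC)c(C(C)(C)O)nc23)ccn1`, changes compound 1 in the same place as compounds 2 and 3: 1-hydroxy-1-methylethyl in place of 3-methyl-1,2-oxazol-5-yl on an aromatic carbon.

Both measured departures from the 3-methyl-1,2-oxazol-5-yl of compound 1 lowered the number in this assay, the cyclopentyl by a large step and the oxolan-3-yl by a modest one. Among the measured compounds shown here, the 1-hydroxy-1-methylethyl is a third departure at the same aromatic carbon, and no measured pair shows this group. A downward step beyond the scatter is therefore expected for compound 4, of a size between the two measured steps rather than exceeding the larger one. The expected step is a number 22 percentage points lower from compound 1 to compound 4 (beyond the scatter).

For compound 4 the estimate in this assay is 40%, with a range from 22% to 58%.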

Compound 4, percent of the compound remaining: 92%
Compound 4: the middle estimate sits 52 percentage points below what was measured; measured number outside the range, above it.
By their numbers in this assay, from the lowest: compound 2; then compound 3; then compound 1; then compound 4.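

Working notes: in this assay, the 1-hydroxy-1-methylethyl gives a number 30 percentage points higher from compound 1 to compound 4 (beyond the scatter), the only upward departure from the 3-methyl-1,2-oxazol-5-yl among the replacements shown at this aromatic carbon, so losing that group does not by itself lower the number. The same group also gives a number 58 percentage points higher from compound 3 to compound 4 (beyond the scatter) and a number 85 percentage points higher from compound 2 to compound 4 (beyond the scatter), so the three replacements at this one place spread widely, and compound 4 stands highest of the four, with its steps to all the others beyond the scatter. Among the compounds shown here, the change swaps a five-membered aromatic ring with 0 hydrogen-bond donors for a group with no ring and 1 hydrogen-bond donor, and these features change together in the single step from compound 1 to compound 4.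

The compounds shown leave open whether the hydroxyl or the branched chain carries the step, a question that a tert-butyl group or the methyl ether of the 1-hydroxy-1-methylethyl at the same carbon would address. No supporting measurement is available to explain the rise in the number.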